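The source may report more compounds than this note shows. Statements on the series, on what has been measured and on what is new or still open speak of the compounds shown alone.

Compound 1, `N#CC1=C(N)Oc2c(c3nc4ccccc4nc3c3ccccc23)C12C(=O)N(Cc1cnnn1-c1cccc(S(N)(=O)=O)c1)c1ccccc12`, gives 44200 nM in a functional assay on A549 cells (Homo sapiens) for antiproliferative activity, read by MTT assay, with a stated time of 48 h; on this read-out higher numbers stand for weaker inhibition and lower numbers for stronger inhibition.
Compound 2, `Cc1ccc(C)c(-n2nncc2CN2C(=O)C3(C(C#N)=C(N)Oc4c3c3nc5ccccc5nc3c3ccccc43)c3ccccc32)c1`, yields only a limit in this assay, > 50000 nM.
Compound 3, `N#CC1=C(N)Oc2c(N)cc3nc4ccccc4nc3c2C12C(=O)N(Cc1cnnn1-c1ccccc1Cl)c1ccccc12`, gives 29800 nM in this assay.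

Compound 3 holds the lowest of the two numbers; compound 1 lies close to it, and that gap stays within the usual scatter, while the remaining entry, for compound 2, is a limit rather than a number. Compound 4, `CCOc1ccc(-n2nncc2CN2C(=O)C3(C(C#N)=C(N)Oc4c(N)cc5nc6ccccc6nc5c43)c3ccccc32)cc1`, differs from compound 3 in one place: 4-ethoxyphenyl in place of 2-chlorophenyl on an aromatic nitrogen. Among the measured compounds shown here, the only measured step that touches the same place is the exchange of the aryl group on that aromatic nitrogen, an at least 1.1-fold higher number from compound 1 to compound 2 (0.05 log units; that floor lies within the scatter); its endpoint is the limit of > 50000 nM in this assay, at which 1 of the 3 values shown sits, so it gives only a floor and no size beyond the scatter. On that basis no shift beyond the scatter is expected in this assay from compound 3 to compound 4, a 1.2-fold higher number from compound 3 to compound 4 (0.07 log units; within the scatter). Compound 4 is therefore estimated at 35000 nM, with a likely range from 15000 nM to 50000 nM.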

Compound 4, half-maximal inhibitory concentration: > 50000 nM
Compound 4: a limit, no number; the forecaster's own chance of this, stated with the estimate: 30%; at least 1.4-fold (0.15 log units) between middle value and limit.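

Compound 4 reaches only a limit in this assay, > 50000 nM. Putting 4-ethoxyphenyl in place of 2-chlorophenyl on the aromatic nitrogen gives an at least 1.6-fold higher number from compound 3 to compound 4 (0.22 log units; that floor lies within the scatter), so this change, too, yields a floor and no size beyond the scatter. An aryl exchange on this nitrogen has now ended at a limit rather than a number twice, on the core of compound 3 as well as on that of compound 1: the limit of > 50000 nM in this assay, at which 2 of the 4 values shown sit.

As far as these compounds go, the true size of this step stays open, as does whether any aryl group on this nitrogen shifts the number beyond the scatter. Equally open, from the compounds shown here alone, is whether a phenyl ring carrying an amine or a carboxylic acid, or a longer chain in place of the ethoxy group, would give a readable number at this position.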